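Methoxy to Chloro: What to Expect for Compound 4

The source may hold more compounds than are shown below. What is called first, only, known or untested is meant among the compounds shown, and "the series" means these compounds.

In a functional assay on BMDM cells (Mus musculus, strain C57BL/6) for inhibition, with a stated time of 2 days (a lower number here means a stronger inhibitor, a higher number a weaker inhibitor), three compounds have been measured so far:

Compound 1 `COc1ccc(-c2cn(CC(=O)Nc3nccs3)nn2)cc1` gives 510 nM.
Compound 2 `COc1ccc(-c2cn(CC(=O)Nc3cc(C)on3)nn2)cc1` gives > 30000 nM, which is a limit of the assay rather than a number.
Compound 3 `COc1ccc(-c2cn(CC(=O)Nc3nc(C)cs3)nn2)cc1` gives 3890 nM.

Compound 3 thus stands highest of the two plain numbers; the only other one comes from compound 1, with a 7.6-fold higher number from compound 1 to compound 3 (0.88 log units; beyond the scatter).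

Compound 4 `Cc1csc(NC(=O)Cn2cc(-c3ccc(Cl)cc3)nn2)n1` differs from compound 3 by chloro in place of methoxy on an aromatic carbon. Going by the values given here, none of the measured steps touches the methoxy: an at least 58-fold higher number from compound 1 to compound 2 (1.76 log units; beyond the scatter) and an at least 7.7-fold lower number from compound 2 to compound 3 (0.88 log units; beyond the scatter) change the group on the amide-type nitrogen, and a 7.6-fold higher number from compound 1 to compound 3 (0.88 log units; beyond the scatter) concerns methyl in place of hydrogen on an aromatic carbon. With no guidance, no step beyond the scatter is expected in this assay. Compound 4 is therefore estimated at 3900 nM, between 1000 nM and 15000 nM, which means a 1.0-fold higher number from compound 3 to compound 4 (0.00 log units; within the scatter) is expected.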

Compound 4, half-maximal inhibitory concentration: 520 nM
Compound 4: middle estimate off by 7.5-fold (0.88 log units), on the high side; the whole stated range lies above it.
By their numbers in this assay, from the lowest: compounds 1 and 4 (each within the scatter of the next); then compound 3. At a limit, above all of these: compound 2.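

The methoxy group on the six-membered aromatic ring had stayed fixed until now, and this result shows that the group at this place matters in this assay: chloro in place of methoxy gives a 7.5-fold lower number from compound 3 to compound 4 (0.87 log units; beyond the scatter). So this position can shift the reading as much as the group on the amide-type nitrogen does. No measured property accounts for the size of this step. Still open, going by these compounds, is how an amine or a carboxylic acid at this place would read. On these data alone, whether chloro gives a similar step alongside other groups on the amide-type nitrogen also remains open.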